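This account rests on a few compounds, and the source may have more. Where it says the series, first, only, none or still open, it means among the compounds named here.

Measured compounds in an assay on A7R5 cells for displacement of a labelled ligand from Endothelin-1 receptor (Rattus norvegicus); a higher number here means a weaker inhibitor, a lower number a stronger inhibitor:
compound 1, `COc1cccc(Sc2c(NS(=O)(=O)c3ccc(C(C)(C)C)cc3)noc2CCCC#N)c1`, gives 1300 nM
compound 2, `COc1cccc(Sc2c(NS(=O)(=O)c3ccc(C(C)(C)C)cc3)noc2CCC/C=N/O)c1`, gives 1500 nM
compound 3, `COC(=O)CCCc1onc(NS(=O)(=O)c2ccc(C(C)(C)C)cc2)c1Sc1cccc(OC)c1`, gives 400 nM

Compound 1 has the second highest of the three numbers. Its nearest neighbour is compound 2, separated by a 1.2-fold higher number from compound 1 to compound 2 (0.06 log units; within the scatter), a difference within the scatter; the furthest is compound 3, reached by a 3.3-fold lower number from compound 1 to compound 3 (0.51 log units; beyond the scatter), a modest step beyond the scatter.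

The next member is compound 4, `COc1cccc(Sc2c(NS(=O)(=O)c3ccc(C(C)(C)C)cc3)noc2CCCC(N)=O)c1`. Relative to compound 1 the change is carbamoyl in place of cyano on a saturated chain carbon, three bonds along the chain from an aromatic carbon.

Two measured steps start from the same cyano group on the same chain carbon. Replacing it by the oxime-bearing chain of compound 2 gave a 1.2-fold higher number from compound 1 to compound 2 (0.06 log units; within the scatter), no change beyond the scatter. Replacing it by methoxycarbonyl gave a 3.3-fold lower number from compound 1 to compound 3 (0.51 log units; beyond the scatter), a modest lower number. Carbamoyl lies between these two cases in what leaves and enters, so a step of at most modest size toward a lower number is expected, a 1.3-fold lower number from compound 1 to compound 4 (0.11 log units; within the scatter), with no change beyond the scatter remaining likely.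

Compound 4 is therefore estimated at 1000 nM in this assay, expected within 400 nM to 2500 nM.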

Compound 4, half-maximal inhibitory concentration: 6300 nM
Compound 4: middle estimate off by 6.3-fold (0.80 log units), on the low side, outside the stated range (above it).
By their numbers in this assay, from the lowest: compound 3; then compounds 1 and 2 (each within the scatter of the next); then compound 4.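

In this assay this place on the chain is sensitive to the terminal group: carbamoyl in place of cyano gives a 4.8-fold higher number from compound 1 to compound 4 (0.69 log units; beyond the scatter), the first step from the nitrile that goes beyond the scatter toward a higher number. The largest contrast lies on the carbonyl carbon, where amino in place of methoxy gives a 16-fold higher number from compound 3 to compound 4 (1.20 log units; beyond the scatter), so ester and primary amide are not interchangeable here. The oxime-bearing chain also differs from the carbamoyl chain, with a 4.2-fold higher number from compound 2 to compound 4 (0.62 log units; beyond the scatter), leaving compound 4 as the weakest of the four.

No evidence on the origin of these differences is available. A carboxylic acid, a dimethylcarbamoyl group or a longer chain ending in carbamoyl would show whether the higher number follows the primary amide specifically or extends to other terminal groups.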